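This account rests on a few compounds, and the source may have more. Where it says the series, first, only, none or still open, it means among the compounds named here.

Compound 1 `S=C1NCCN1Cc1ccc(Cl)cc1` carries a chloro group on its aromatic ring, and in a functional assay on B16 cells (Mus musculus) for inhibition, with a stated time of 72 h (a lower number here means a stronger inhibitor, a higher number a weaker inhibitor), compound 1 gives 4300 nM. Compound 2 `COc1ccc(CN2CCNC2=S)cc1` differs from it by methoxy in place of chloro on an aromatic carbon. In this assay compound 2 reaches only a limit of the assay, > 10000 nM. The step is an at least 2.3-fold higher number from compound 1 to compound 2 (0.36 log units; beyond the scatter); because compound 2 sits at the limit of > 10000 nM in this assay, at which 1 of the 3 values shown sits, only the lower end of that step is known. Compound 3 `S=C1NCCCN1Cc1ccc(Cl)cc1` has a different core from compound 1; the difference between the two cores is not broken down here. In this assay compound 3 gives 2400 nM, a value within the scatter of compound 1. Compound 4 `COc1ccc(CN2CCCNC2=S)cc1` has not yet been measured; it differs from compound 3 by methoxy in place of chloro on an aromatic carbon. The surroundings are not identical, since in compound 1 the group sits para to a group of 7 heavy atoms and in compound 3 para to a group of 8 heavy atoms, so this is the same kind of change, not the same. The step expected is a 3.8-fold higher number from compound 3 to compound 4 (0.57 log units; beyond the scatter), resting on an at least 2.3-fold higher number from compound 1 to compound 2 (0.36 log units; beyond the scatter). Compound 4 is therefore expected near 9000 nM, between 4500 nM and 25000 nM.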

Compound 4, half-maximal inhibitory concentration: 6100 nM
For compound 4 the middle estimate is 1.5-fold (0.17 log units) above the measured one, and the stated range covers the measured number.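

In this assay methoxy in place of chloro gives a 2.5-fold higher number from compound 3 to compound 4 (0.41 log units; beyond the scatter) and so a weaker inhibitor on this core too. Compound 2 gives > 10000 nM in this assay and this is a limit of the assay, not a number. The change therefore carries over from one core to the other in direction for these two pairs of compounds, but a matching size is not shown, and two pairs make no rule for the whole series: the same change on two cores in this assay, an at least 2.3-fold higher number (0.36 log units; beyond the scatter) from compound 1 to compound 2 and a 2.5-fold higher number (0.41 log units; beyond the scatter) from compound 3 to compound 4; the limit leaves it open whether they differ

The compounds shown leave open why methoxy gives the higher number, and whether the trend reaches other groups on the aromatic ring, such as fluoro, methyl, an amine or a carboxylic acid. They also leave open whether a longer chain in place of the single carbon that joins the aromatic ring to the core would keep the same order of chloro and methoxy.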